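Swapping a Pentylcarbonyl for a Sulfamoyl Group

The source may report more compounds than this note shows. Statements on the series, on what has been measured and on what is new or still open speak of the compounds shown alone.

Compound 3 `CCCCCC(=O)N[C@@H]1CCN(c2cc(C)nn3c(-c4ccc(OC)c(OC)c4)c(C)nc23)C1` stands at a limit in an ADME assay on microsomes from liver (Mus musculus) for metabolic stability, read by LC-MS, with NADPH named in the record, with a stated time of 60 min, tested at 1 uM, in the absence of a further agent (on this read-out higher numbers stand for a more stable compound and lower numbers for a less stable compound), giving > 95% rather than a measured number. Compound 1 `CSc1ccc(-c2c(C)nc3c(N4CC[C@@H](NC(C)=O)C4)cc(C)nn23)cc1` also gives only the limit > 95% in this assay. Compound 2 `CC(=O)N[C@@H]1CCN(c2cc(C)nn3c(-c4nccs4)c(C)nc23)C1` likewise returns the limit > 95%. The step that the two limits leave unreadable from compound 1 to compound 2 therefore cannot be sized, since (the limit of > 95% in this assay, at which 3 of the 3 values shown sit). Compound 4 `COc1ccc(-c2c(C)nc3c(N4CC[C@@H](NS(N)(=O)=O)C4)cc(C)nn23)cc1OC` differs from compound 3 by sulfamoyl in place of pentylcarbonyl on an amine nitrogen. No measured step bears on this change, and the single step shown is unreadable. With nothing pointing either way, compound 4 is expected to remain close to the same limit, so the estimated step of a number no higher from compound 3 to compound 4 (the limit leaves the size open) is expected to be negligible. Compound 4 is estimated at 95%, with a range from 82% to 99%.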

Compound 4, percent of the compound remaining: > 95%
Compound 4 ended at the assay's limit; the forecaster's own chance of this, stated with the estimate: 75%; the middle value lies on the limit itself.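

No step can be read from compound 3 to compound 4, since both stop at a limit rather than a measured number: the limit of > 95% in this assay, at which 4 of the 4 values shown sit.

The compounds shown leave open whether swapping pentylcarbonyl for sulfamoyl changes stability in this assay at all.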